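Moving the bromine on the anilino ring of compound 2

This account rests on a few compounds, and the source may have more. Where it says the series, first, only, none or still open, it means among the compounds named here.

Measured so far in a functional assay on NCI-H1299 cells (Homo sapiens) for antiproliferative activity, read by MTT assay, with a stated time of 72 h; on this read-out lower numbers stand for stronger inhibition and higher numbers for weaker inhibition:
compound 1, `CC(C)OC1=C(C(=O)c2ccccc2)C(c2ccc(Br)cc2)N(CCCn2ccnc2)C1=O`: 18900 nM
compound 2, `O=C(C1=C(Nc2cccc(Br)c2)C(=O)N(CCCn2ccnc2)C1c1ccc(Br)cc1)c1ccccc1`: 11500 nM

Within the data shown here, on these two numbers compound 2 gives the lower one, but the only measured step, a 1.6-fold lower number from compound 1 to compound 2 (0.22 log units; within the scatter), lies within the scatter, so the two compounds cannot be ranked. Compound 3 `O=C(C1=C(Nc2ccccc2Br)C(=O)N(CCCn2ccnc2)C1c1ccc(Br)cc1)c1ccccc1` differs from compound 2 by 2-bromophenyl in place of 3-bromophenyl on an amine nitrogen. Among the measured compounds shown here, no measured step bears on this change; the single known step concerns a different position and is itself within the scatter. Compound 3 is therefore expected to stay close to compound 2, with a step of a 1.0-fold higher number from compound 2 to compound 3 (0.02 log units; within the scatter). The estimate for compound 3 in this assay is 12000 nM, within a range of 5000 nM to 30000 nM.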

Compound 3, half-maximal inhibitory concentration: 15600 nM
The estimate for compound 3 lay 1.3-fold (0.11 log units) below the measured number; the range from low to high includes it.
By their numbers in this assay, from the lowest: compounds 2, 3 and 1 (each within the scatter of the next).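

In this assay, 2-bromophenyl in place of 3-bromophenyl on the amine nitrogen gives a 1.4-fold higher number from compound 2 to compound 3 (0.13 log units; within the scatter) and so shows that this shift of the bromine stays within the scatter. The exchange of isopropoxy for (2-bromophenyl)amino gives a 1.2-fold lower number from compound 1 to compound 3 (0.08 log units; within the scatter) and also stays within the scatter, as the exchange for (3-bromophenyl)amino did. No measurement at hand offers an explanation for these results. The compounds shown leave open whether a phenyl ring without bromine, or one carrying an amine or a carboxylic acid in place of the bromine, would move the number beyond the scatter.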